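The source may report more compounds than this note shows. Statements on the series, on what has been measured and on what is new or still open speak of the compounds shown alone.

Measured so far:
Compound 1 `CC(C)n1ncc2c(C(=O)Nc3ccccc3)cccc21` in a functional assay on HepG2 cells (Homo sapiens) for inhibition, read by MTT assay, with a stated time of 72 h (on this read-out higher numbers stand for weaker inhibition and lower numbers for stronger inhibition), gives 23700 nM.
Compound 2 `Cc1ccc(-n2cc(CNC(=O)c3cccc4c3cnn4C(C)C)nn2)c(C)c1` in this assay gives only a limit, > 40000 nM.

Compound 2 thus has no number of its own; its value sits at the limit of > 40000 nM in this assay, at which 1 of the 2 values shown sits. Compound 3 `CC(C)n1ncc2c(C(=O)NCc3cn(-c4ccc([N+](=O)[O-])cc4)nn3)cccc21` differs from compound 2 in one place: 4-nitrophenyl in place of 2,4-dimethylphenyl on an aromatic nitrogen. Among the compounds with values here, no measured pair shows what such a swap does here, so in this assay no shift beyond the scatter is expected. The expected step is a number no higher from compound 2 to compound 3 (the limit leaves the size open). Compound 3 is therefore estimated at about 40000 nM, likely between 15000 nM and 100000 nM, and may well come back as a limit again.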

Compound 3, half-maximal inhibitory concentration: > 40000 nM
Compound 3: only a limit was reported (the forecaster's own chance of this, stated with the estimate: 60%); the middle value lies on the limit itself.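

Compound 2 and compound 3 both end at a limit of the assay rather than a number, so no step can be read between them: the limit of > 40000 nM in this assay, at which 2 of the 3 values shown sit. The compounds shown leave open whether 4-nitrophenyl in place of 2,4-dimethylphenyl changes anything in this assay.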